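Thiophen-2-yl in place of 1H-pyrrol-2-yl: compound 4

The source may report more compounds than this note shows. Statements on the series, on what has been measured and on what is new or still open speak of the compounds shown alone.

Compound 1 `COC1=CC(c2cc3ccccc3[nH]2)=N/C1=C\c1ccc[nH]1` gives 13200 nM in a functional assay on PLC5 cells (Homo sapiens) for cytotoxicity, read by MTT assay; a lower number here means a stronger inhibitor, a higher number a weaker inhibitor.
Compound 2 `COC1=CC(c2cc3ccccc3n2C(=O)OC(C)(C)C)=N/C1=C\c1ccc[nH]1` reaches only a limit of this assay, > 40000 nM.
Compound 3 `COC1=CC(c2cc3ccccc3[nH]2)=N/C1=C\c1ccc(-c2cc3ccccc3[nH]2)[nH]1` gives 15900 nM in this assay.

Compound 1 holds the lowest of the two numbers in hand; compound 3 is nearest, and the step from compound 1 to compound 3 is a 1.2-fold higher number from compound 1 to compound 3 (0.08 log units; within the scatter). Compound 2 sits at the limit of > 40000 nM in this assay, at which 1 of the 3 values shown sits, so the step from compound 1 to compound 2 is an at least 3.0-fold higher number from compound 1 to compound 2 (0.48 log units; beyond the scatter).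

Compound 4 `COC1=CC(c2cc3ccccc3[nH]2)=N/C1=C\c1cccs1` differs from compound 1 by thiophen-2-yl in place of 1H-pyrrol-2-yl on a double-bonded chain carbon bound to a double-bonded ring carbon. Neither measured step touches this exchange directly: the step to compound 2 alters the aromatic nitrogen of the other ring and weakens, while the step to compound 3 builds onto the 1H-pyrrol-2-yl unit itself and stays within the scatter. The exchange removes the unit the step to compound 3 left intact, so an expectation can only be loose.

Compound 4 is expected to give 20000 nM in this assay, with a range from 8000 nM to 50000 nM. The estimated step is a 1.5-fold higher number from compound 1 to compound 4 (0.18 log units; within the scatter), a weakening not clearly beyond the scatter.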

Compound 4, half-maximal inhibitory concentration: > 40000 nM
Compound 4: a limit, no number; the forecaster's own chance of this, stated with the estimate: 25%; middle value at least 2.0-fold (0.30 log units) away from the limit.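

Exchanging the 1H-pyrrol-2-yl unit for thiophen-2-yl on a double-bonded chain carbon bound to a double-bonded ring carbon gives an at least 3.0-fold higher number from compound 1 to compound 4 (0.48 log units; beyond the scatter) in this assay, so at this position one five-membered aromatic ring with 1 hetero atom does not stand in for the other. Compound 4 gives > 40000 nM, which is a limit of the assay. Compound 3 keeps the 1H-pyrrol-2-yl unit and builds onto it, with a 1.2-fold higher number from compound 1 to compound 3 (0.08 log units; within the scatter), so building onto that unit and replacing it read differently here.

The exchange changes the hetero atom and the hydrogen-bond donor count together, and the compounds shown do not separate the two. A furan-2-yl unit, or an imidazol-2-yl unit that retains a ring nitrogen hydrogen, would bear on that question.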